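The compounds below may be only part of what the source reports. "The series", "measured", "known", "first", "only" and "open" are said of these compounds alone.

Compound 3 `CC(c1ccc(-c2ccccc2)c(F)c1)c1nnc2n1N=C(c1ccc(Br)cc1)CS2` gives 3700 nM in a functional assay on HepG2 cells (Homo sapiens) for inhibition, read by sulforhodamine B assay, with a stated time of 72 h (on this read-out lower numbers stand for stronger inhibition and higher numbers for weaker inhibition), the lowest of the three numbers shown, though compound 2 `CC(c1ccc(-c2ccccc2)c(F)c1)c1nnc2n1N=C(c1ccc(Cl)cc1)CS2` with 6700 nM sits within the scatter of it, and only compound 1 `CC(c1ccc(-c2ccccc2)c(F)c1)c1nnc2n1N=C(c1ccc(Cl)cc1Cl)CS2` with 8600 nM lies beyond the scatter. Compound 4 `CC(c1ccc(-c2ccccc2)c(F)c1)c1nnc2n1N=C(c1ccc(F)cc1)CS2` differs from compound 3 by fluoro in place of bromo on an aromatic carbon. The nearest guide is the halogen swap a 1.8-fold lower number from compound 2 to compound 3 (0.26 log units; within the scatter), which stayed within the scatter; a 1.3-fold lower number from compound 1 to compound 2 (0.11 log units; within the scatter) was likewise small, and only a 2.3-fold lower number from compound 1 to compound 3 (0.37 log units; beyond the scatter) reached a modest size. Swapping one halogen for another has thus not moved this assay beyond the scatter here. Compound 4 is therefore expected to show a 1.6-fold higher number from compound 3 to compound 4 (0.21 log units; within the scatter), a small rise at most. The estimate for compound 4 is 6000 nM, in a range of 2500 nM to 14000 nM.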

Compound 4, half-maximal inhibitory concentration: 5100 nM
Beside the measured number, compound 4's estimate is 1.2-fold (0.07 log units) above it; low and high end bracket the measured number.
By their numbers in this assay, from the lowest: compounds 3, 4, 2 and 1 (each within the scatter of the next, the first and the last beyond it).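

In this assay the halogens at this aromatic carbon now include fluoro, and neither the change from bromo (a 1.4-fold higher number from compound 3 to compound 4 (0.14 log units; within the scatter)) nor the change from chloro (a 1.3-fold lower number from compound 2 to compound 4 (0.12 log units; within the scatter)) leaves the scatter, so fluoro, chloro and bromo cannot be told apart at this place. The change from 2,4-dichlorophenyl to 4-fluorophenyl (a 1.7-fold lower number from compound 1 to compound 4 (0.23 log units; within the scatter)) also stays within the scatter, unlike the change to 4-bromophenyl. No measurement offered here explains these values. The compounds shown leave open whether a non-halogen group at this carbon, such as an amine or a carboxylic acid, would move the number beyond the scatter.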